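This account rests on a few compounds, and the source may have more. Where it says the series, first, only, none or still open, it means among the compounds named here.

The series rests on the shared core of compound 1 `Cc1ccc(NC(=O)N[C@H](C)c2ccccc2)cc1`, which in an ADME assay on the whole organism with Oryza sativa as the target, tested at 1 uM (on this read-out higher numbers stand for a weaker effect at the one concentration tested and lower numbers for a stronger effect), gives 98%. Compound 2 `Cc1ccc(NC(=O)N[C@@H](C)c2ccccc2)cc1` gives 99% in this assay, and compound 3 `CCc1cccc(NC(=O)N[C@H](C)c2ccccc2)c1` gives 71%. Compound 1 thus stands second highest of the three numbers: compound 2 lies nearest, compound 3 furthest, its value beyond the scatter from that of compound 1. Among the compounds with values here, the one step between compounds that differ in a single place is a number 1 percentage points higher from compound 1 to compound 2 (within the scatter), a difference within the scatter; the fact that compounds 1 and 2 differ only in the configuration as drawn is all that separates the pair. Compound 1 and compound 3 differ in more than one place, so their values are set side by side without a step being drawn between them.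

The next compound, compound 4 `CC(C)c1ccc(NC(=O)N[C@H](C)c2ccccc2)cc1`, differs from compound 1 by isopropyl in place of methyl on an aromatic carbon. Within the data shown here, the only measured step, that from compound 1 to compound 2, concerns configuration and not the substituent on the aromatic ring, so it does not bear on this change; no measured step does. Compound 3, carrying a larger alkyl elsewhere on the ring, shows the lower value 71%, which is weak guidance at best. For compound 4 the expectation is a moderate downward step, a number 13 percentage points lower from compound 1 to compound 4 (beyond the scatter), with wide uncertainty. Compound 4 is estimated at 85%, between 55% and 100%.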

Compound 4, a percentage reported as activity, at one concentration (the size of the read-out at that concentration, not a potency): 79%
For compound 4 the middle estimate is 6 percentage points above the measured one; the range from low to high includes it.
By their numbers in this assay, from the lowest: compounds 3 and 4 (each within the scatter of the next); then compounds 1 and 2 (each within the scatter of the next).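

Within the data shown here, on an aromatic carbon para to a large group, isopropyl in place of methyl gives the first readable step at this position in this assay: a number 19 percentage points lower from compound 1 to compound 4 (beyond the scatter). Among these compounds, the earlier single-place step concerned only configuration and stayed within the scatter, so this is the first sign that the read-out responds to a change in the structure of the shared core, here towards a stronger effect at the one concentration tested. Nothing on hand bears on why this substituent change moves the number, and the step records the size of the shift without giving a cause.

A single pair cannot show whether the number keeps falling as the alkyl group grows, or whether a tert-butyl group, a longer chain, a methoxy group, an amine or a carboxylic acid at this place would push it further down or bring it back up. Also open, on these data alone, is whether the configuration of the saturated chain carbon still makes no difference with isopropyl on the ring, since the pair that speaks to this carries methyl.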